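Swapping fluoro for methoxy on the shared core

The source may hold more compounds than are shown below. What is called first, only, known or untested is meant among the compounds shown, and "the series" means these compounds.

In a functional assay on HeLa cells (Homo sapiens) for cytotoxicity, read by MTT assay, with a stated time of 48 h (a lower number here means a stronger inhibitor, a higher number a weaker inhibitor), compound 2 `O=C(O)CN1C(=O)/C(=C/c2nc3ccc(F)cc3n2Cc2ccccc2F)SC1=S` shows only a limit (> 50000 nM) and not a number. Compound 3 `COc1ccc2nc(/C=C3\SC(=S)N(CC(=O)O)C3=O)n(Cc3ccccc3F)c2c1` keeps the rest of compound 2 but has methoxy in place of fluoro on an aromatic carbon. For the measured compounds named here, compound 1 `COc1ccc2nc(/C=C3\SC(=S)N(CC(=O)O)C3=O)n(Cc3ccc(C)cc3)c2c1` also carries methoxy on the core, with a different side group, and gives a true number (6440 nM) that serves as the only guide here. A clear gain in strength is therefore expected in this assay (an at least 3.3-fold lower number from compound 2 to compound 3 (0.52 log units; beyond the scatter)). Compound 3 is estimated at 15000 nM in a range from 5000 nM to 45000 nM in this measurement.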

Compound 3, half-maximal inhibitory concentration: 28100 nM
Compound 3: the middle estimate sits 1.9-fold (0.27 log units) below what was measured; the range from low to high includes it.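

In this assay compound 2 gives only a limit, not a true number: the limit of > 50000 nM in this assay, at which 1 of the 3 values shown sits.

With methoxy in place of fluoro on this aromatic carbon, a true number appears, and the change reads as an at least 1.7-fold lower number from compound 2 to compound 3 (0.25 log units; that floor lies within the scatter), so a real gain is not yet established. The side group also counts: with methoxy kept on the core, 2-fluorophenyl in place of 4-methylphenyl gives a 4.4-fold higher number from compound 1 to compound 3 (0.64 log units; beyond the scatter).

Going by these compounds, the true size of the methoxy step stays open, as does whether an amine or ethoxy on this carbon would behave like methoxy.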